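Sulfonamide variation on a shared quinoline thiourea core

The source may hold more compounds than are shown below. What is called first, only, known or untested is meant among the compounds shown, and "the series" means these compounds.

Three compounds have numbers or outcomes in a functional assay on MDA-MB-231 cells (Homo sapiens) for antiproliferative activity, read by sulforhodamine B assay, with a stated time of 48 h; a lower number here means a stronger inhibitor, a higher number a weaker inhibitor. Compound 3 `O=S(=O)(Nc1nccs1)c1ccc(N/C(S)=N\c2ccnc3cc(C(F)(F)F)ccc23)cc1` gives 24400 nM in this assay. Compound 1 `Nc1ccc(S(=O)(=O)Nc2ccnc3cc(C(F)(F)F)ccc23)cc1` gives 31000 nM in this assay, and the gap between compound 3 and compound 1 lies within the usual scatter, so no order between them is claimed. Compound 2 `N=C(N)NS(=O)(=O)c1ccc(N/C(S)=N\c2ccnc3cc(C(F)(F)F)ccc23)cc1` is recorded in this assay as "not active" (no number reported), without a number. For the measured compounds named here, no single-change step between measured compounds exists, so nothing calibrates the next change. Compound 4 `COc1cc(NS(=O)(=O)c2ccc(N/C(S)=N\c3ccnc4cc(C(F)(F)F)ccc34)cc2)nc(OC)n1` differs from compound 3 by 2,6-dimethoxypyrimidin-4-yl in place of 1,3-thiazol-2-yl on a sulfonamide nitrogen. The expected step of a 1.2-fold lower number from compound 3 to compound 4 (0.09 log units; within the scatter) is modest, toward a slightly lower number or none beyond the scatter. Compound 4 is estimated at 20000 nM, with a range from 7000 nM to 60000 nM.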

Compound 4, half-maximal inhibitory concentration: 52100 nM
Estimate against measurement, compound 4: 2.6-fold (0.42 log units) below; low and high end bracket the measured number.
By their numbers in this assay, from the lowest: compounds 3, 1 and 4 (each within the scatter of the next, the first and the last beyond it).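

For the compounds shown here, the step of a 2.1-fold higher number from compound 3 to compound 4 (0.33 log units; beyond the scatter) in this assay is the first single-change reading, and it is modest. At this sulfonamide nitrogen, 2,6-dimethoxypyrimidin-4-yl in place of 1,3-thiazol-2-yl is not tolerated without cost, so the position responds to the choice of aromatic ring and its substituents. Nothing measured on these compounds accounts for the step.

Going by these compounds, it remains open whether the ring itself or its methoxy groups carry the step. An unsubstituted pyrimidine ring, or an acetyl group on this nitrogen, would help separate these contributions.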